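The source may report more compounds than this note shows. Statements on the series, on what has been measured and on what is new or still open speak of the compounds shown alone.

Compound 1, `Cn1c(Cc2nn(CCCO)c(=O)c3ccccc23)nnc1SCC(=O)Nc1ccc(Cl)cc1Cl`: in an assay on NK92 cells for inhibition of interleukin-15 (Homo sapiens), read by AlphaScreen, with stated times of 30 min and 1 h (on this read-out higher numbers stand for weaker inhibition and lower numbers for stronger inhibition), compound 1 gives 30000 nM.
Compound 2, `Cn1c(Cc2nn(CCCO[Si](C)(C)C(C)(C)C)c(=O)c3ccccc23)nnc1SCCCCCCCC(=O)Nc1ccc(Cl)cc1Cl`: in this assay compound 2 gives > 30000 nM, which is a limit of the assay and not a number.

Compound 2 thus stands at the limit of > 30000 nM in this assay, at which 1 of the 2 values shown sits. Compound 3, `Cn1c(Cc2nn(CCCO)c(=O)c3ccccc23)nnc1SCCCCCCCC(=O)Nc1ccc(Cl)cc1Cl`, differs from compound 2 by a hydrogen atom in place of a group of 7 heavy atoms (6 carbon, 1 silicon; no ring), on an oxygen on a saturated carbon. Within the data shown here, no measured step of this kind exists here, and compound 1, which carries the same free hydroxyl on a shorter chain, sits at the edge of the assay range. Compound 3 is therefore expected to show a step of a number no higher from compound 2 to compound 3 (the limit leaves the size open), none beyond the scatter. Compound 3 is estimated at 30000 nM, between 10000 nM and 100000 nM.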

Compound 3, half-maximal inhibitory concentration: > 30000 nM
Compound 3: no number, only a limit; the forecaster's own chance of this, stated with the estimate: 60%; the middle value lies on the limit itself.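

Compound 2 and compound 3 both give a limit of the assay and not a number, and no step can be read between them: the limit of > 30000 nM in this assay, at which 2 of the 3 values shown sit.

The compounds shown leave open what replacing the group of 7 heavy atoms with a hydrogen atom does in this assay.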